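The compounds below may be only part of what the source reports. "The series", "measured", "known", "first", "only" and "open" are said of these compounds alone.

Measured in an ADME assay on MT4 cells (Homo sapiens) for cytotoxicity, read by MTT assay, with a stated time of 4 days; a lower number here means that less compound is tolerated, a higher number that more compound is tolerated:
compound 1 `N#Cc1ccc(Nc2nc(Oc3ccc(Cl)cc3Cl)c3ccccc3n2)cc1` gives 32000 nM
compound 2 `COc1ccc(Oc2nc(Nc3ccc(C#N)cc3)nc3ccccc23)cc1` gives 340000 nM
compound 3 `Cc1cccc(C)c1Oc1nc(Nc2ccc(C#N)cc2)nc2ccccc12` gives 35000 nM

Compound 3 stands second highest of these three numbers in this assay: its value and that of compound 1 lie within the scatter of each other, while compound 2 lies well apart, as a 9.7-fold lower number from compound 2 to compound 3 (0.99 log units; beyond the scatter) shows. The three compounds share one core and differ only in the aryl group on an oxygen on an aromatic ring.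

Compound 4 `N#Cc1ccc(Nc2nc(Oc3c(Br)cc(Br)cc3Br)c3ccccc3n2)cc1` differs from compound 3 in that (2,4,6-tribromophenyl in place of 2,6-dimethylphenyl on an oxygen on an aromatic ring). Among the compounds with values here, two measured steps bear on this exchange. a 1.1-fold higher number from compound 1 to compound 3 (0.04 log units; within the scatter) shows that replacing 2,4-dichlorophenyl with 2,6-dimethylphenyl changed little, whereas an 11-fold higher number from compound 1 to compound 2 (1.03 log units; beyond the scatter) shows that 4-methoxyphenyl stands far apart from both. Since 2,4,6-tribromophenyl, with its three bromines, resembles the 2,4-dichlorophenyl of compound 1 and its 32000 nM rather than the methoxy-bearing ring of compound 2, only a small step is expected in this assay, if any beyond the scatter, and if so toward a lower number. Compound 4 is therefore expected to give 25000 nM, with a range from 8000 nM to 60000 nM. The step this estimate means is expected to be a 1.4-fold lower number from compound 3 to compound 4 (0.15 log units; within the scatter).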

Compound 4, half-maximal cytotoxic concentration: 58000 nM
Beside the measured number, compound 4's estimate is 2.3-fold (0.37 log units) below it; measured number inside the range.
By their numbers in this assay, from the lowest: compounds 1, 3 and 4 (each within the scatter of the next); then compound 2.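

In this assay the 2,4,6-tribromophenyl group becomes a third aryl group on this oxygen that cannot be separated from the others: a 1.7-fold higher number from compound 3 to compound 4 (0.22 log units; within the scatter) and a 1.8-fold higher number from compound 1 to compound 4 (0.26 log units; within the scatter) both stay within the scatter. Only the 4-methoxyphenyl group remains apart, as a 5.9-fold lower number from compound 2 to compound 4 (0.77 log units; beyond the scatter) shows, so rings carrying three bromines, two chlorines or two methyl groups cannot be told apart in this assay. Nothing measured here explains why compound 2 stands apart from the other three. As far as these compounds go, it remains open whether a ring carrying an amine or a carboxylic acid would sit with compound 2 or with the other three. Within the data shown here, with only one methoxy-bearing compound, it is also unclear whether the high number of compound 2 is special to the 4-methoxyphenyl group.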